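A few compounds are considered here, and "the series" means these few. Any claim that something is new, unique, unknown or untested is made for them only; others in the source may bear on it.

Two amino acid conjugates of a shared core have been tested so far. In a functional assay on MDA-MB-453 cells (Homo sapiens) for cytotoxicity, read by MTT assay, with a stated time of 72 h (on this read-out lower numbers stand for stronger inhibition and higher numbers for weaker inhibition), compound 1 `CC1=CCC[C@H]2[C@](C)(CC3=CC(=O)C(N4CCC[C@H]4C(=O)O)=CC3=O)[C@@H](C)CC[C@]12C` gives 60600 nM and compound 2 `CC1=CCC[C@H]2[C@](C)(CC3=CC(=O)C=C(N[C@@H](CC(C)C)C(=O)O)C3=O)[C@@H](C)CC[C@]12C` gives 10900 nM. Compound 2 therefore holds the lower of the two numbers, and its gap to compound 1 lies beyond the scatter.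

Compound 3 `CC1=CCC[C@H]2[C@](C)(CC3=CC(=O)C=C(NCC(=O)O)C3=O)[C@@H](C)CC[C@]12C` has not yet been measured in this assay. It differs from compound 2 by hydrogen in place of isobutyl on a saturated chain carbon bound to an amine nitrogen and a carbonyl carbon, so that (1-carboxy-3-methylbutyl)amino becomes (carboxymethyl)amino.

For the measured compounds named here, no two measured compounds differ in one place only, so no measured step guides this change and the expectation remains a judgement. It rests on compound 2 at 10900 nM, which carries the isobutyl, and on compound 1 at 60600 nM, which lacks it but also differs elsewhere. A moderate loss is expected, with the estimate being a 2.6-fold higher number from compound 2 to compound 3 (0.41 log units; beyond the scatter), towards a higher number and beyond the scatter. The expected value for compound 3 is 28000 nM, with an estimated range from 11000 nM to 70000 nM.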

Compound 3, half-maximal inhibitory concentration: 5840 nM
Compound 3: the middle estimate sits 4.8-fold (0.68 log units) above what was measured; the measured number lies below the stated range.
By their numbers in this assay, from the lowest: compounds 3 and 2 (each within the scatter of the next); then compound 1.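

In this assay, for the compounds shown here, hydrogen in place of isobutyl on a saturated chain carbon bound to an amine nitrogen and a carbonyl carbon gives a 1.9-fold lower number from compound 2 to compound 3 (0.27 log units; within the scatter), and this is the first step that changes one place only. On this pair, the isobutyl with its 4 carbon atoms and the bare hydrogen cannot be told apart, so the isobutyl is not needed for compound 2 to reach a value of this size, and (1-carboxy-3-methylbutyl)amino and (carboxymethyl)amino serve alike here. No measurement on hand bears on why the two compounds read so alike.

From the compounds shown here alone, a single pair says little about the wider range of groups on this carbon, so it remains open whether a methyl, a benzyl or a longer chain would also leave the reading in place. Also open, going by these compounds, is what a methyl ester or an amide in place of the carboxylic acid would do, and compound 1 differs from compound 2 and compound 3 in more than one place, so it cannot settle either question.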